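The compounds below may be only part of what the source reports. "The series", "measured", "known", "first", "only" and "open" are said of these compounds alone.

Of the compounds shown here, two have been measured. Compound 1 `CC(C)(C)N(NC(=O)c1ccccc1)C(=O)c1ccccc1Br` gives 170 nM in an assay on cells for agonist activity at ecdysone receptor (Bombyx mori), read by a luciferase reporter, with a stated time of 24 h; on this read-out lower numbers stand for an effect already at smaller amounts and higher numbers for an effect only at larger amounts of compound. Compound 2 `Cc1ccccc1C(=O)NN(C(=O)c1ccccc1Cl)C(C)(C)C` gives 72.4 nM in this assay, the lowest of the two numbers; its gap to compound 1 lies beyond the scatter. Compound 3 `CC(C)(C)N(NC(=O)c1ccc(C#N)cc1)C(=O)c1ccccc1Cl` has not been measured. It differs from compound 2 in one place: 4-cyanophenyl in place of 2-methylphenyl on a carbonyl carbon. Going by the values given here, no step of this kind has been measured, so the expected change is uncertain. A modest rise toward a larger amount is expected, estimated at about a 2.1-fold higher number from compound 2 to compound 3 (0.32 log units; beyond the scatter). Compound 3 is therefore estimated at 150 nM, with a range from 40 nM to 600 nM.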

Compound 3, half-maximal effective concentration: 603 nM
Compound 3: the middle estimate sits 4.0-fold (0.60 log units) below what was measured; measured number above the stated range.
By their numbers in this assay, from the lowest: compound 2; then compound 1; then compound 3.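

In this assay this place on a carbonyl carbon proves sensitive to what it carries: 4-cyanophenyl in place of 2-methylphenyl gives an 8.3-fold higher number from compound 2 to compound 3 (0.92 log units; beyond the scatter) in the number. Going by these compounds alone, compounds 1 and 2 differ in more than one place, so this is the first single change that can be read, and it moves the number upward. No measurement at hand gives a reason for the step.

Going by these compounds, whether 2-cyanophenyl or 4-methylphenyl here would read like compound 2 or compound 3 stays open. The loss of the methyl, the arrival of the nitrile and the change of ring position therefore cannot yet be told apart.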